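A few compounds are considered here, and "the series" means these few. Any claim that something is new, unique, unknown or untested is made for them only; others in the source may bear on it.

Measured compounds:
- compound 1, `Cc1c(C)c2c(c(C)c1OC(=O)CCC(=O)O)CCC(C)(C(=O)NC1CC(C)(C)N([O])C1(C)C)O2`: 205000 nM
- compound 2, `Cc1c(C)c2c(c(C)c1OC(=O)CCC(=O)NC1CC(C)(C)N([O])C(C)(C)C1)CC[C@@](C)(CCC[C@H](C)CCC[C@H](C)CCCC(C)C)O2`: 146000 nM
- compound 3, `CC1(C)CC(NC(=O)CCC(=O)O)C(C)(C)N1[O]`: > 400000 nM

In a functional assay on CEM13 cells (Homo sapiens) for cytotoxicity, read by MTT assay, with a stated time of 72 h (on this read-out higher numbers stand for weaker inhibition and lower numbers for stronger inhibition), compound 2 gives 146000 nM. Going by the values given here, the only other number here is that of compound 1, which in this assay gives 205000 nM; the two values lie within the usual scatter of each other, so neither can be called the stronger. For compound 3 this assay reports only a limit, > 400000 nM, not a number (the limit of > 400000 nM in this assay, at which 1 of the 3 values shown sits).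

The unmeasured compound 4, `Cc1c(C)c2c(c(C)c1OC(=O)CCC(=O)NC1CC(C)(C)N([O])C1(C)C)CC[C@@](C)(CCC[C@H](C)CCC[C@H](C)CCCC(C)C)O2`, shares the core of compound 2 and differs from it in one place: a group of 10 heavy atoms (8 carbon, 1 nitrogen, 1 oxygen; one five-membered non-aromatic ring with 1 hetero atom) in place of a group of 11 heavy atoms (9 carbon, 1 nitrogen, 1 oxygen; one six-membered non-aromatic ring with 1 hetero atom), on an amide-type nitrogen. Among the compounds with values here, no measured pair shows this exact change, so the data give no basis for a step beyond the scatter in either direction. The expectation for compound 4 is therefore a value close to that of compound 2, with the step of a 1.0-fold higher number from compound 2 to compound 4 (0.01 log units; within the scatter) expected to stay within the scatter. In this assay compound 4 is estimated at 150000 nM, with a likely range from 70000 nM to 320000 nM.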

Compound 4, half-maximal inhibitory concentration: > 300000 nM
Compound 4: a limit, no number; the forecaster's own chance of this, stated with the estimate: 15%; at least 2.0-fold (0.30 log units) between middle value and limit.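

Replacing the one six-membered non-aromatic ring with 1 hetero atom by the one five-membered non-aromatic ring with 1 hetero atom, on an amide-type nitrogen, is not a neutral change in this assay: the result is an at least 2.0-fold higher number from compound 2 to compound 4 (0.31 log units; beyond the scatter). In this assay compound 4 gives only a limit, not a number: the limit of > 300000 nM in this assay, at which 1 of the 4 values shown sits. Going by these compounds alone, the earlier compounds offered no pair differing in one place, so this is the first sign that the ring on this nitrogen matters on the shared core.

On these data alone, the true size of the step stays open. Nothing shown gives a cause for the step. It is also unknown whether a tert-butyl group or a seven-membered ring on the same nitrogen would behave like compound 2 or like compound 4.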